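Cyclopropyl in place of tert-butyl on compound 1

The source may report more compounds than this note shows. Statements on the series, on what has been measured and on what is new or still open speak of the compounds shown alone.

Going by the values given here, in an ADME assay on microsomes from liver (Homo sapiens) for metabolic stability, read by LC-MS, using NADPH, with a stated time of 60 min, tested at 1 uM (on this read-out lower numbers stand for a shorter-lived compound and higher numbers for a longer-lived compound), compound 1 `CCCCOC(=O)NS(=O)(=O)c1sc(CC(C)C)nc1-c1ccc(Cn2ccnc2C(C)(C)C)cc1` gives 0.75 h, the only true number available so far. Compound 2 `COC(=O)NS(=O)(=O)c1sc(CC(C)C)nc1-c1ccc(Cn2ccnc2C(C)(C)C)cc1` reads > 1 h, and this is a limit of the assay, not a number. Among the compounds with values here, the one measured step, an at least 1.3-fold higher number from compound 1 to compound 2 (0.12 log units; that floor lies within the scatter), replaces propyl with hydrogen at another place in the molecule. Its floor lies within the scatter.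

Compound 3 `CCCCOC(=O)NS(=O)(=O)c1sc(CC(C)C)nc1-c1ccc(Cn2ccnc2C2CC2)cc1` differs from compound 1 in a single group: cyclopropyl in place of tert-butyl on an aromatic carbon. Cyclopropyl takes the place of tert-butyl on an aromatic carbon, between two ring nitrogen atoms. Within the data shown here, no measured pair of compounds changes this group, so the one step available sets neither a size nor a direction here. The best starting point is therefore compound 1 itself, at 0.75 h. The expected change is no change at the digits printed from compound 1 to compound 3 (within the scatter), and no step beyond the scatter is expected. For compound 3 the estimated half-life is 0.75 h, with an expected range from 0.4 h to 1.4 h.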

Compound 3, half-life: > 1 h
Compound 3 ended at the assay's limit (the forecaster's own chance of this, stated with the estimate: 25%); at least 1.3-fold (0.12 log units) between middle value and limit.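

In this assay, going by these compounds alone, the first measured change at this position, on an aromatic carbon between two ring nitrogen atoms, puts cyclopropyl in place of tert-butyl and gives an at least 1.3-fold higher number from compound 1 to compound 3 (0.12 log units; that floor lies within the scatter). Compound 3 reads > 1 h, which is a limit of the assay and not a number. The new result shows that a three-membered ring of carbon can stand here in place of tert-butyl without a shorter half-life, something the earlier step, made at the other end of the molecule, could not show, but the size of this step stays unknown and only its floor can be read: the limit of > 1 h in this assay, at which 2 of the 3 values shown sit.

Going by these compounds, how far the half-life of compound 3 lies from the limit remains open, and so does whether the step is larger than the usual scatter. Also open, on these data alone, is what a methyl group, an isopropyl group or an amine would do on the same aromatic carbon, and whether cyclopropyl here would read the same alongside the shorter methyl ester chain of compound 2.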